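This account rests on a few compounds, and the source may have more. Where it says the series, first, only, none or still open, it means among the compounds named here.

Measured so far in a functional assay on the whole organism with Mus musculus as the target, in the maximal electroshock model; on this read-out lower numbers stand for an effect already at smaller amounts and higher numbers for an effect only at larger amounts of compound
compound 1 `CC1CCSC1=O` gives 91 mg/kg
compound 2 `CC(C)C1CCSC1=O` gives > 500 mg/kg

Compound 2 stands at > 500 mg/kg and this is a limit of the assay, not a number. Compound 3 `CC(C)(C)C1CCSC1=O` follows from compound 2 through methyl in place of hydrogen on a saturated chain carbon bound to two saturated chain carbons and a saturated ring carbon and the change is methyl in place of hydrogen on a saturated chain carbon bound to two saturated chain carbons and a saturated ring carbon. Among the measured compounds shown here, one measured step bears on this change: isopropyl in place of methyl on a saturated ring carbon, which gave an at least 5.4-fold higher number from compound 1 to compound 2 (0.73 log units; beyond the scatter) and so ran towards larger amounts of compound. A single step makes no pattern, and its size is known only as a lower bound. For the measured compounds named here, with an at least 5.4-fold higher number from compound 1 to compound 2 (0.73 log units; beyond the scatter) as the only guide, a further rise or no step beyond the scatter is expected in this assay for compound 3, with no return towards the value of compound 1. The estimated change is a number no higher from compound 2 to compound 3 (the limit leaves the size open) and it stays rough. Its starting point has no exact number, and a limit reading for compound 3 is also a real prospect. For compound 3 the expected value is 500 mg/kg with 200 mg/kg to 1000 mg/kg as the estimated range.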

Compound 3, dose for half-maximal effect: > 500 mg/kg
Compound 3: a limit, no number; the forecaster's own chance of this, stated with the estimate: 55%; the middle value lies on the limit itself.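

No new step can be read from compound 2 to compound 3 in this assay, because both readings are limits of the assay and not numbers: the limit of > 500 mg/kg in this assay, at which 2 of the 3 values shown sit.

The compounds shown leave open where compound 2 and compound 3 truly lie, and whether methyl in place of hydrogen changes the dose needed at all.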